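The source may hold more compounds than are shown below. What is called first, only, known or untested is meant among the compounds shown, and "the series" means these compounds.

Measured compounds:
compound 1 `Cc1ccc(/C=C/C(=O)Oc2ccc(/C=C3\CCCCC3=O)cc2)cc1`, 230000 nM
compound 2 `COc1ccc(/C=C/C(=O)Oc2ccc(/C=C3\CCCCC3=O)cc2)cc1`, 8780 nM
compound 3 `Cc1ccc(C(=O)Oc2ccc(/C=C3\CCCCC3=O)cc2)cc1`, 22700 nM

All three were run in a functional assay on CCRF-CEM cells (Homo sapiens); on this read-out higher numbers stand for weaker inhibition and lower numbers for stronger inhibition. The pair compound 1 and compound 2 share one core and differ by the change (methoxy in place of methyl on an aromatic carbon); this step gave a 26-fold lower number from compound 1 to compound 2 (1.42 log units; beyond the scatter). Compound 3 sits on a different core; the difference between the core of compound 1 and the core of compound 3 is not broken down here. Compound 3 gives 22700 nM, which stands between the other two measured numbers.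

Compound 4 `COc1ccc(C(=O)Oc2ccc(/C=C3\CCCCC3=O)cc2)cc1` is not yet measured. Among the compounds with values here, it is built from compound 3 by the change (methoxy in place of methyl on an aromatic carbon), the same change as the one made between compound 1 and compound 2, with the same surroundings at the place. Within the data shown here, with only one earlier example of this change, and that on another core, the expectation leans on a single step.

For compound 4 the estimate is 3000 nM in this assay, with a range from 700 nM to 12000 nM. Among the measured compounds shown here, this means an expected step of a 7.6-fold lower number from compound 3 to compound 4 (0.88 log units; beyond the scatter), taken to be somewhat smaller than the earlier one because the core of compound 3 differs and the earlier step of a 26-fold lower number from compound 1 to compound 2 (1.42 log units; beyond the scatter) is the only guide.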

Compound 4, half-maximal inhibitory concentration: 36100 nM
The estimate for compound 4 lay 12-fold (1.08 log units) below the measured number; measured number outside the range, above it.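

In this assay, replacing 4-methylphenyl with 4-methoxyphenyl on the core of compound 3 gave a 1.6-fold higher number from compound 3 to compound 4 (0.20 log units; within the scatter), so this pair offers no sign of a gain from methoxy. Set beside the earlier step on the other core, the same replacement did not carry over from one core to the other: the same change on two cores in this assay, a 26-fold lower number (1.42 log units; beyond the scatter) from compound 1 to compound 2 and a 1.6-fold higher number (0.20 log units; within the scatter) from compound 3 to compound 4, 42-fold (1.62 log units) apart, beyond the scatter of two such steps. This shows that the large step on the core of compound 1 cannot be taken as a general property of the methyl-to-methoxy replacement in this series, but with a single pair on each core it does not show which feature of the cores lies behind the gap, nor how the replacement would behave on any third core.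

Still open, from the compounds shown here alone, is how each core responds to other groups at the same place on the aromatic ring, such as a chlorine atom, a hydroxyl, an amine or a longer chain like ethoxy, which would show whether the core of compound 1 is unusually responsive or the methoxy result is a single case. Also open, going by these compounds, is whether the two cores would still differ with an amide in place of the ester.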